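A few compounds are considered here, and "the series" means these few. Any claim that something is new, unique, unknown or untested is made for them only; others in the source may bear on it.

Compound 1 `O=C(Nc1cccc(-n2cc(-c3ccncc3)c(-c3ccc(Cl)c(O)c3)n2)c1)Nc1cccc(C(F)(F)F)c1` in a functional assay on MCF7 cells (Homo sapiens) for inhibition, read by sulforhodamine B assay, with a stated time of 48 h (on this read-out higher numbers stand for lower toxicity in this test and lower numbers for higher toxicity in this test), reaches only the limit of > 32500 nM, not a number. Compound 2 `COc1cc(-c2nn(-c3cccc(NC(=O)Nc4cc(C(F)(F)F)cc(C(F)(F)F)c4)c3)cc2-c2ccncc2)ccc1Cl` in this assay likewise reaches only the limit of > 50000 nM. Within the data shown here, compound 2 therefore stands at a limit, and the one further value shown is a limit too (the limit of > 32500 nM in this assay, at which 1 of the 2 values shown sits, (the limit of > 50000 nM in this assay, at which 1 of the 2 values shown sits)), so no measured step between compounds that differ in one place is available. Compound 3 `O=C(Nc1cccc(-n2cc(-c3ccncc3)c(-c3ccc(Cl)c(O)c3)n2)c1)Nc1cc(C(F)(F)F)cc(C(F)(F)F)c1` differs from compound 2 in a single place: hydrogen in place of methyl on an oxygen on an aromatic ring. Among the measured compounds shown here, with no measured step to draw on, no size can be read from the numbers; as both measured values sit at limits, a change beyond the usual scatter in this assay is not expected in either direction, and compound 3 is expected to end at a limit as well. The estimate for compound 3 in this assay is 50000 nM (20000 nM to 150000 nM). That estimate means an expected step of a number no higher from compound 2 to compound 3 (the limit leaves the size open).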

Compound 3, concentration lethal to 50% of the cells: 31500 nM
Compound 3: middle estimate off by 1.6-fold (0.20 log units), on the high side; the measured number falls inside the stated range.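

In this assay compound 3 gives 31500 nM, the first number among the compounds shown rather than a limit. Going from methoxy to hydroxy on the 4-chloro-3-methoxyphenyl group gives an at least 1.5-fold lower number from compound 2 to compound 3 (0.20 log units; that floor lies within the scatter), and trifluoromethyl in place of hydrogen on an aromatic carbon gives an at least 1.0-fold lower number from compound 1 to compound 3 (0.01 log units; that floor lies within the scatter). Both steps are floors that start from a limit, so neither shows a change beyond the scatter, and the true size of each could be larger.

The compounds shown leave open how large these two steps really are. They also leave open what an amine or an ethoxy group would give in place of the hydroxy group of compound 3 on this aromatic ring.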